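Replacing the 2,3-dichlorophenyl Group of Compound 1

The source may hold more compounds than are shown below. What is called first, only, known or untested is meant among the compounds shown, and "the series" means these compounds.

In a functional assay (strain AB) with Danio rerio as the target, read by microscopy, with a stated time of 1 h (a lower number here means that less compound is needed, a higher number that more compound is needed for the effect), compound 1 `CCN1CCc2c(sc(NC(=O)Nc3cccc(Cl)c3Cl)c2C(N)=O)C1` gives 17400 nM, the higher of the two actual numbers obtained so far. Compound 2 `CCN1CCc2sc(NC(=O)Nc3ccc(Cl)cc3)c(C(N)=O)c2CC1` gives 5800 nM, a lower number by a margin beyond the scatter, so less of it is needed for the effect. Compound 3 `CC1CCc2nc(NC(=O)Nc3ccc(Cl)cc3)sc2C1` returned only a limit, > 25000 nM, and no actual number.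

The next compound to be tested is compound 4 `CCN1CCc2c(sc(NC(=O)Nc3cccc(C)c3)c2C(N)=O)C1`, which has not yet been measured in this assay. It keeps the core of compound 1 and carries 3-methylphenyl in place of 2,3-dichlorophenyl on an amide-type nitrogen. Within the data shown here, no measured pair isolates this change, so its size cannot be read directly from the data. Compound 2, at 5800 nM, shows that a lower number is reachable among these compounds, but it differs from compound 1 in more than the aromatic group. Only a modest move towards a lower number is therefore expected, one that may well stay within the scatter. The expected step is a 1.7-fold lower number from compound 1 to compound 4 (0.24 log units; within the scatter). For compound 4 the estimated value is 10000 nM, with an expected range from 3500 nM to 25000 nM.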

Compound 4, half-maximal effective concentration: 13000 nM
Compound 4: middle estimate off by 1.3-fold (0.11 log units), on the low side, within the range that was stated.
By their numbers in this assay, from the lowest: compound 2; then compounds 4 and 1 (each within the scatter of the next). At a limit, above all of these: compound 3.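

In this assay, among these compounds, the exchange of 2,3-dichlorophenyl for 3-methylphenyl on the amide-type nitrogen gives a 1.3-fold lower number from compound 1 to compound 4 (0.13 log units; within the scatter), and this is the first comparison here in which only one place differs. It shows that, on the core of compound 1, this position can carry an aromatic group without chlorine and still give a measurable value, with no change that can be told from the scatter of repeated measurements. Compound 3 stands at a limit and not at an actual number, and no single-place pair links it to this change: the limit of > 25000 nM in this assay, at which 1 of the 4 values shown sits.

The compounds shown leave open whether a quite different group on this nitrogen, such as a pyridine ring, a carboxylic acid, an amine or a longer chain, would move the number beyond the scatter, since both aromatic groups compared here are substituted phenyl rings. They also leave open what a single change elsewhere on the shared core would do, and the steps between the other compounds cannot be read, as those compounds differ in more than one place.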